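This account rests on a few compounds, and the source may have more. Where it says the series, first, only, none or still open, it means among the compounds named here.

Compound 2 `CCOc1ccc(NCN2C(=O)c3ccccc3C2=O)cc1` gives the lowest of the two numbers in an assay on isolated protein for inhibition of ribosomal protein S6 kinase alpha-2 (Homo sapiens), read by fluorescence, with a stated time of 20 min (on this read-out higher numbers stand for weaker inhibition and lower numbers for stronger inhibition), at 590 nM. Among the measured compounds shown here, compound 1 `O=C1c2ccccc2C(=O)N1CNc1ccc(F)cc1` gives 8740 nM in this assay, and the single measured step, a 15-fold lower number from compound 1 to compound 2 (1.17 log units; beyond the scatter), concerns a group on the other aromatic ring. Compound 3 `CCOc1ccc(NCN2C(=O)c3cccc(NC(=O)c4ccccc4)c3C2=O)cc1` differs from compound 2 by benzamido in place of hydrogen on an aromatic carbon. No measured step touches that ring, so nothing shown bears directly on the change. The number for compound 3 is therefore expected near that of compound 2, with a 1.3-fold lower number from compound 2 to compound 3 (0.12 log units; within the scatter) as a guess. Compound 3 is estimated at 450 nM, between 100 nM and 2000 nM.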

Compound 3, half-maximal inhibitory concentration: 1340 nM
Compound 3: middle estimate off by 3.0-fold (0.47 log units), on the low side; low and high end bracket the measured number.
By their numbers in this assay, from the lowest: compound 2; then compound 3; then compound 1.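

In this assay, among the compounds shown here, the ring of the shared core that no earlier step touched now has a measured change: benzamido in place of hydrogen on an aromatic carbon gives a 2.3-fold higher number from compound 2 to compound 3 (0.36 log units; beyond the scatter). This position therefore carries benzamido, with its added six-membered aromatic ring, at a modest cost in the number. Nothing shown gives a reason for this rise. The compounds shown leave open how an amine, acetamido or a carboxylic acid on the same carbon would compare with compound 2. They also leave open whether benzamido would shift the number similarly with fluoro in place of ethoxy.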